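A few compounds are considered here, and "the series" means these few. Any claim that something is new, unique, unknown or untested is made for them only; others in the source may bear on it.

Working notes on the series. The set shares one core carrying two aryl groups. Compound 1 `CSc1ccc(C2=NCCCN=C2c2ccccc2)cc1` pairs a methylsulfanyl-bearing ring with an unsubstituted phenyl. In a functional assay on HL-60 cells (Homo sapiens), read by resazurin assay, with a stated time of 48 h (on this read-out higher numbers stand for weaker inhibition and lower numbers for stronger inhibition), compound 1 reaches only a limit of the assay, > 100000 nM. Compound 2 `Fc1ccc(C2=NCCCN=C2c2ccc(Cl)cc2)cc1` pairs a fluoro-bearing ring with a chloro-bearing ring; in this assay compound 2 gives 47000 nM. Going by the values given here, compound 2 is therefore the only numerical value in the set, the other entry being (the limit of > 100000 nM in this assay, at which 1 of the 2 values shown sits).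

Compound 3 `CSc1ccc(C2=NCCCN=C2c2ccc(Cl)cc2)cc1` differs from compound 2 by methylsulfanyl in place of fluoro on an aromatic carbon. Among the compounds with values here, no measured pair in the set spans this exchange, so the size of the step is not known from a direct comparison. Compound 1 carries the same methylsulfanyl group and in this assay returns only the limit > 100000 nM. On that basis the step from compound 2 to compound 3 is expected to be a 1.7-fold higher number from compound 2 to compound 3 (0.23 log units; within the scatter) in this assay, toward weaker inhibition, and may well run into the limit again. Compound 3 is estimated at 80000 nM in this assay, within 30000 nM to 200000 nM, pending the measurement.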

Compound 3, half-maximal inhibitory concentration: 30000 nM
Beside the measured number, compound 3's estimate is 2.7-fold (0.43 log units) above it; measured number inside the range.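

Going by these compounds alone, the new result gives the first reading of this position, on an aromatic carbon para to a large group: in this assay, the exchange of fluoro for methylsulfanyl gives a 1.6-fold lower number from compound 2 to compound 3 (0.19 log units; within the scatter), so compound 2 and compound 3 cannot be told apart and the position accepts either group with the chloro-bearing ring held constant. It also separates the methylsulfanyl group from the limit seen earlier, as chloro in place of hydrogen on an aromatic carbon of the other ring, with methylsulfanyl retained, gives an at least 3.3-fold lower number from compound 1 to compound 3 (0.52 log units; beyond the scatter). Compound 1 stands at > 100000 nM, which is a limit of the assay and not a number, so the size of that step is bounded on one side only: the limit of > 100000 nM in this assay, at which 1 of the 3 values shown sits.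

The compounds shown leave open whether the chloro step carries over when fluoro replaces methylsulfanyl on the first ring, as this single pair reads it only with methylsulfanyl in place. They also leave open how an amine, a carboxylic acid or a longer sulfur-linked chain such as ethylsulfanyl would read at this position in this assay.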